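The source may report more compounds than this note shows. Statements on the series, on what has been measured and on what is new or still open speak of the compounds shown alone.

Working notes on the series in an ADME assay on microsomes from liver (Homo sapiens) for metabolic stability, with a stated time of 60 min, tested at 1 uM; on this read-out lower numbers stand for a less stable compound and higher numbers for a more stable compound.

Compound 1 `CNc1nc2c(-c3ccnc(OC)c3)cnn2cc1OC` gives 63% in this assay, the highest of the two numbers in hand; the nearest neighbour is compound 2 `COc1cc(-c2cnn3cc(OC)c(C(C)C)nc23)ccn1`, which gives 40%. Going by the values given here, the one measured step, a number 23 percentage points lower from compound 1 to compound 2 (beyond the scatter), puts isopropyl in place of methylamino on an aromatic carbon.

Compound 3 `COc1cc(-c2cnn3cc(OC)c(C)nc23)ccn1` is not yet measured. Against compound 1 it differs by methyl in place of methylamino on an aromatic carbon. The step from compound 1 to compound 2 is the only one that bears on this: it likewise removes methylamino from the same aromatic carbon, there for isopropyl, and it lowered the percent remaining beyond the scatter. Among the compounds with values here, for methyl entering at the same position a step in the same downward direction is therefore expected, of similar or somewhat smaller size, since no second step is available to calibrate the size more closely. The estimated step is a number 15 percentage points lower from compound 1 to compound 3 (beyond the scatter). For compound 3 the expected value in this assay is 48%, with a range from 32% to 64%.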

Compound 3, percent of the compound remaining: 44%
For compound 3 the middle estimate is 4 percentage points above the measured one; the measured number falls inside the stated range.
By their numbers in this assay, from the lowest: compounds 2 and 3 (each within the scatter of the next); then compound 1.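

In this assay, the loss seen on replacing methylamino is not particular to isopropyl: a number 19 percentage points lower from compound 1 to compound 3 (beyond the scatter) with the smaller methyl on the same aromatic carbon, so both alkyl replacements now lie on the same side of compound 1. Between the two alkyl groups themselves, a number 4 percentage points higher from compound 2 to compound 3 (within the scatter) and so methyl and isopropyl are not separated at this position, which makes the gap to compound 1 a contrast between methylamino and these two alkyl groups rather than a trend with alkyl size. The data shown contain no measurement that would explain why compound 1 keeps the higher number.

Still open, on these data alone, is whether a primary amine, dimethylamino, methoxy or a longer alkylamino chain on this aromatic carbon would group with compound 1 or with compounds 2 and 3, which would help separate the role of the ring-bound nitrogen from that of the hydrogen-bond donor counted in methylamino. As far as these compounds go, all three compounds also share the rest of the core of compound 1, so it remains open whether the same contrast holds when the methoxy group on the same six-membered ring is replaced.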